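Replacing 3-Fluorocyclobutyl with Oxan-2-yl on the Amide

This account rests on a few compounds, and the source may have more. Where it says the series, first, only, none or still open, it means among the compounds named here.

Compound 1 `C(#Cc1nc2c(s1)CN(C1CCCCC1)CC2)c1ccccc1` gives > 10000 nM in an assay on HEK293 cells for negative allosteric modulation of metabotropic glutamate receptor 5 (Homo sapiens), read by FLIPR, with a stated time of 1 h; a higher number here means a weaker inhibitor, a lower number a stronger inhibitor.
Compound 2 `O=C(C1CCC1)N1CCc2nc(C#Cc3ccccc3)sc2C1` gives 370 nM in this assay.
Compound 3 `O=C(C1CC(F)C1)N1CCc2nc(C#Cc3ccccc3)sc2C1` gives > 10000 nM in this assay.

The value of compound 1 is a limit of the assay, not a number. The value of compound 3 is likewise only a limit. Compound 3 therefore stands at the limit, sharing it with compound 1 (the limit of > 10000 nM in this assay, at which 2 of the 3 values shown sit); compound 2 is the only one of the three with a measured number.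

Compound 4 `O=C(C1CCCCO1)N1CCc2nc(C#Cc3ccccc3)sc2C1` differs from compound 3 by oxan-2-yl in place of 3-fluorocyclobutyl on a carbonyl carbon. Going by the values given here, two measured steps bear on this position. The step of an at least 27-fold lower number from compound 1 to compound 2 (1.43 log units; beyond the scatter) shows that a cyclobutylcarbonyl on the ring nitrogen brings the number down sharply, and the step of an at least 27-fold higher number from compound 2 to compound 3 (1.43 log units; beyond the scatter) shows that a fluoro on that ring sends it back to the limit. Among the compounds with values here, no measured step covers oxan-2-yl, so the expected size of the step is uncertain; a drop from the limit toward the region of compound 2 is thought plausible but far from sure. The expected step is an at least 3.3-fold lower number from compound 3 to compound 4 (0.52 log units; beyond the scatter). Compound 4 is estimated at 3000 nM, between 500 nM and 20000 nM.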

Compound 4, half-maximal inhibitory concentration: > 10000 nM
Compound 4 was reported as a limit (the forecaster's own chance of this, stated with the estimate: 35%); at least 3.3-fold (0.52 log units) between middle value and limit.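

In this assay compound 4 is reported only as a limit, which puts it with compound 1 and compound 3: the limit of > 10000 nM in this assay, at which 3 of the 4 values shown sit. Oxan-2-yl in place of cyclobutyl on the carbonyl carbon gives an at least 27-fold higher number from compound 2 to compound 4 (1.43 log units; beyond the scatter), so a second group at this place, and one without fluorine, also loses the measured activity of compound 2. The steps from compound 1 and from compound 3 to compound 4 join two limits and cannot be read, so oxan-2-yl and 3-fluorocyclobutyl cannot be ranked against each other.

The compounds shown leave open whether ring size or the ring oxygen matters here, since oxan-2-yl differs from cyclobutyl in both. A cyclohexyl or an oxetan-3-yl on the carbonyl carbon would separate the two.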